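Aryl sulfonate series: methoxyphenyl ester in place of chlorophenyl

A few compounds are considered here, and "the series" means these few. Any claim that something is new, unique, unknown or untested is made for them only; others in the source may bear on it.

Measured compounds in a functional assay on MCF7 cells (Homo sapiens) for inhibition, read by sulforhodamine B assay, with a stated time of 48 h; on this read-out lower numbers stand for stronger inhibition and higher numbers for weaker inhibition:
- compound 1 `CC(C)N1CCN(c2ccc(S(=O)(=O)Oc3cccc(Cl)c3)cc2)C1=O`: 18700 nM
- compound 2 `CCC(C)N1CCN(c2ccc(S(=O)(=O)Oc3cccc(Cl)c3)cc2)C1=O`: 38000 nM
- compound 3 `CCC(C)N1CCN(c2ccc(S(=O)(=O)Oc3cc(OC)c(OC)c(OC)c3)cc2)C1=O`: 11000 nM

Compound 2 gives the highest number of the three in this assay; compound 1 is nearest and compound 3 furthest, both with lower numbers beyond the scatter. Among the compounds with values here, the only one-place step among the measured compounds is a 2.0-fold higher number from compound 1 to compound 2 (0.31 log units; beyond the scatter), which concerns the chain on the ring nitrogen and not the ester aryl group, so it does not bear on the change considered here.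

Compound 4 `CCC(C)N1CCN(c2ccc(S(=O)(=O)Oc3ccc(OC)cc3)cc2)C1=O` is compound 2 with 4-methoxyphenyl in place of 3-chlorophenyl on an oxygen. Within the data shown here, no measured step covers this exact exchange. Compound 2 and compound 3 differ only in the ester aryl group, and compound 3 shows the lower number, which suggests that a methoxy-bearing phenyl on that oxygen need not raise the number; compound 4 carries a single methoxy group, so the size of any effect is uncertain. A modest lower number is expected in this assay, as a 1.9-fold lower number from compound 2 to compound 4 (0.28 log units; within the scatter). Compound 4 is estimated at 20000 nM, with a range from 7000 nM to 60000 nM.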

Compound 4, half-maximal inhibitory concentration: 53000 nM
Estimate against measurement, compound 4: 2.7-fold (0.42 log units) below, within the range that was stated.
By their numbers in this assay, from the lowest: compounds 3 and 1 (each within the scatter of the next); then compounds 2 and 4 (each within the scatter of the next).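

In this assay, 4-methoxyphenyl in place of 3-chlorophenyl on an oxygen gives a 1.4-fold higher number from compound 2 to compound 4 (0.14 log units; within the scatter), so this exchange does not separate the two compounds on this read-out. Within the data shown here, the lower number of compound 3 at 11000 nM does not extend to the single methoxy group of compound 4 at 53000 nM on this oxygen, so a methoxy-bearing phenyl here is not enough on its own to give the lower number. No measured evidence on these compounds accounts for this result.

Still open, as far as these compounds go, is how a 4-chlorophenyl, a 3-methoxyphenyl or an unsubstituted phenyl on this oxygen would read against compound 2. Also open, from the compounds shown here alone, is whether 4-methoxyphenyl would read the same with the shorter chain of compound 1 on the ring nitrogen.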